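The source may report more compounds than this note shows. Statements on the series, on what has been measured and on what is new or still open speak of the compounds shown alone.

Measured so far:
Compound 1 `CCOC(=O)c1ccc(-c2nn(C)c3ccccc23)cc1` in a functional assay on cells (Platelet, Homo sapiens) for inhibition (a lower number here means a stronger inhibitor, a higher number a weaker inhibitor), gives > 10000 nM, which is a limit of the assay and not a number.
Compound 2 `CCOC(=O)c1ccc(-c2nn(Cc3cccc(Cl)c3)c3ccccc23)cc1` in this assay gives > 10000 nM, again only a limit.
Compound 3 `CCOC(=O)c1ccc(-c2nn(Cc3ccccc3OC)c3ccccc23)cc1` in this assay gives > 10000 nM, again only a limit.

Compound 3 therefore stands nowhere on a scale of numbers: it sits at the limit, as do the two others (the limit of > 10000 nM in this assay, at which 3 of the 3 values shown sit). The three steps among the measured compounds, a step that the two limits leave unreadable from compound 1 to compound 2, a step that the two limits leave unreadable from compound 1 to compound 3 and a step that the two limits leave unreadable from compound 2 to compound 3, are each unreadable for the same reason, since both ends of each step are limits. Nothing shown separates the compounds from one another.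

The next compound, compound 4 `CCOC(=O)c1ccc(-c2nn(Cc3cccc(OC)c3)c3ccccc23)cc1`, differs from compound 3 in one place: 3-methoxyphenyl in place of 2-methoxyphenyl on a saturated chain carbon bound to an aromatic nitrogen. For the measured compounds named here, no measured step bears on this change, and no measured step has a readable size at all. With every shown value at the limit (the limit of > 10000 nM in this assay, at which 3 of the 3 values shown sit), the only defensible expectation for this assay is that compound 4 will also fall at or near that limit, with no readable step beyond the scatter in either direction. Compound 4 is accordingly expected to give about 15000 nM, in a range from 3000 nM to 80000 nM. This expectation corresponds to an estimated step that the limit leaves unreadable from compound 3 to compound 4.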

Compound 4, half-maximal inhibitory concentration: > 10000 nM
Compound 4: a limit, no number (the forecaster's own chance of this, stated with the estimate: 80%); the middle value does not contradict the limit.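

No new step can be read between compound 4 and compound 1, compound 2 or compound 3, because both ends of each step are limits of the assay and not numbers: the limit of > 10000 nM in this assay, at which 4 of the 4 values shown sit.

The compounds shown leave open whether any group on the saturated chain carbon bound to an aromatic nitrogen gives a number rather than a limit in this assay.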